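Replacing the bromophenyl sulfide with a butyl chain

The source may report more compounds than this note shows. Statements on the series, on what has been measured and on what is new or still open speak of the compounds shown alone.

In a functional assay on HepG2 cells (Homo sapiens) for cytotoxicity, read by MTT assay, with a stated time of 48 h (a higher number here means a weaker inhibitor, a lower number a stronger inhibitor), compound 2 `O=C(CSc1ccc(Br)cc1)N1N=C(c2cc3ccccc3oc2=O)C[C@@H]1c1ccc(C(F)(F)F)cc1` gives 12700 nM, the highest of the three numbers measured. Compound 1 `CC1=NN(C(=O)CSc2ccccc2)[C@@H](c2cc(Br)cc(Br)c2O)C1` gives 10400 nM, and compound 3 `O=C(CSc1ccc([N+](=O)[O-])cc1)N1N=C(c2cc3ccccc3oc2=O)C[C@@H]1c1ccc(C(F)(F)F)cc1` gives 7760 nM; both lie within the scatter of compound 2. Among the measured compounds shown here, the only single-site step measured, a 1.6-fold lower number from compound 2 to compound 3 (0.21 log units; within the scatter), concerns butyl in place of 4-bromophenyl on a sulfur only indirectly, since it alters the aromatic ring that compound 4 `CCCCSCC(=O)N1N=C(c2cc3ccccc3oc2=O)C[C@@H]1c1ccc(C(F)(F)F)cc1` no longer carries. For the measured compounds named here, no measured step exchanges an aromatic group for a chain on this sulfur, so the direction of any change is unknown and a step of a 1.1-fold lower number from compound 2 to compound 4 (0.02 log units; within the scatter) is expected, nothing beyond the scatter. Compound 4 is therefore estimated at 12000 nM, between 4000 nM and 40000 nM.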

Compound 4, half-maximal inhibitory concentration: 8680 nM
Beside the measured number, compound 4's estimate is 1.4-fold (0.14 log units) above it; the range from low to high includes it.
By their numbers in this assay, from the lowest: compounds 3, 4, 1 and 2 (each within the scatter of the next).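

Compound 4 is the only compound shown that carries a chain rather than an aromatic ring on this sulfur, and in this assay the steps of a 1.5-fold lower number from compound 2 to compound 4 (0.17 log units; within the scatter) and a 1.1-fold higher number from compound 3 to compound 4 (0.05 log units; within the scatter) both stay within the scatter. The aromatic ring on this sulfur, whether it carries bromo or nitro, is therefore not required for cytotoxicity at this level, and butyl serves equally well with the shared core held constant. No measurement shown bears on the reason for this. Still open, going by these compounds, is whether a longer chain, or a chain ending in an amine or a carboxylic acid, would give a step beyond the scatter.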